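Replacing a Piperidinyl Ring With a Dimethylamino Group

The source may hold more compounds than are shown below. What is called first, only, known or untested is meant among the compounds shown, and "the series" means these compounds.

Of the compounds shown here, three sharing one core have been measured in a functional assay on HCT-116 cells (Homo sapiens) for cytotoxicity, with a stated time of 48 h; a higher number here means a weaker inhibitor of growth, a lower number a stronger inhibitor of growth. Compound 1 `Nc1nc(NC2CCCCC2)cc(-c2cc(N3C[C@H](O)[C@@H](O)C3)ccc2O)n1` gives 900 nM in this assay. Compound 3 `Nc1nc(-c2cc(N3C[C@H](O)[C@@H](O)C3)ccc2O)cc(C2CCCCCC2)n1` gives 300 nM in this assay. Compound 2 `Nc1nc(-c2cc(N3C[C@H](O)[C@@H](O)C3)ccc2O)cc(C2CCCNC2)n1` returns only a limit in this assay, > 10000 nM, which is the limit of the measurement and not a number. Compound 2 therefore stands at the limit of > 10000 nM in this assay, at which 1 of the 3 values shown sits, above both of its neighbours. The two steps from it are large: an at least 11-fold higher number from compound 1 to compound 2 (1.04 log units; beyond the scatter), and an at least 33-fold lower number from compound 2 to compound 3 (1.52 log units; beyond the scatter).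

The unmeasured compound 4 `CN(C)c1cc(-c2cc(N3C[C@H](O)[C@@H](O)C3)ccc2O)nc(N)n1` departs from compound 2 at the same spot. dimethylamino in place of piperidin-3-yl on an aromatic carbon

Both steps that involve compound 2 move away from piperidin-3-yl and both lower the number well beyond the scatter, so exchanging that ring for dimethylamino is expected to lower the number as well, though the step to the smaller dimethylamino group need not match the large step seen toward cycloheptyl. The expected step is an at least 3.3-fold lower number from compound 2 to compound 4 (0.52 log units; beyond the scatter). Compound 4 is estimated to give 3000 nM in this assay, within a range of 800 nM to 10000 nM.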

Compound 4, concentration for 50% growth inhibition: > 10000 nM
Compound 4: a limit, no number; the forecaster's own chance of this, stated with the estimate: 30%; middle value at least 3.3-fold (0.52 log units) from the limit.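

In this assay compound 4 gives > 10000 nM, which is a limit of the assay and not a number. The step between compound 2 and compound 4 cannot be read, and the two now stand together at the top of the series: the limit of > 10000 nM in this assay, at which 2 of the 4 values shown sit. The readable steps show that a nitrogen on the aromatic carbon does not by itself hold growth inhibition at this position, and neither does a group with no ring and no hydrogen-bond donor: dimethylamino gives an at least 11-fold higher number from compound 1 to compound 4 (1.04 log units; beyond the scatter), and against the all-carbon ring it gives an at least 33-fold higher number from compound 3 to compound 4 (1.52 log units; beyond the scatter).

On these data alone, how far compound 2 and compound 4 lie past the limit remains unknown, so their order cannot be told. As far as these compounds go, it also remains open whether the cycloalkyl ring is what keeps the number low, which a cyclohexyl or cyclopentylamino group, a diethylamino group or a longer alkyl chain at the same position would help to settle, while a 1-methylpiperidin-3-yl group would test whether the ring's hydrogen-bond donor matters.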